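From Compound 1 to Compound 3: Amino in Place of Chloro

This account rests on a few compounds, and the source may have more. Where it says the series, first, only, none or still open, it means among the compounds named here.

Measured compounds:
compound 1, `Cc1cc(NCc2ccccn2)n2ncc(-c3cccc(Cl)c3)c2n1`: < 5000 nM
compound 2, `Cc1cc(NCc2ncnn2C)n2nc(C)c(-c3ccccc3)c2n1`: 185000 nM

In a physicochemical assay for solubility, read by HPLC, using the shake flask method, measured as kinetic solubility, with a stated time of 2 h, at pH 7.4 (a higher number here means a more soluble compound, a lower number a less soluble compound), compound 1 gives only a limit of the assay, < 5000 nM, and so stands at the limit of < 5000 nM in this assay, at which 1 of the 2 values shown sits. Compound 2 gives 185000 nM in this assay. Compound 3, `Cc1cc(NCc2ccccn2)n2ncc(-c3cccc(N)c3)c2n1`, differs from compound 1 by amino in place of chloro on an aromatic carbon, a 3-chlorophenyl becoming a 3-aminophenyl. Among the compounds with values here, no measured step between two compounds is available, so the expectation rests on the change alone: a step upward in this assay beyond the usual scatter is expected, an at least 6.0-fold higher number from compound 1 to compound 3 (0.77 log units; beyond the scatter). Compound 3 is estimated at 30000 nM, within a range of 5000 nM to 150000 nM.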

Compound 3, solubility: 160000 nM
Compound 3: middle estimate off by 5.3-fold (0.73 log units), on the low side; measured number above the stated range.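

In this assay, the change from 3-chlorophenyl to 3-aminophenyl on the shared core gives an at least 32-fold higher number from compound 1 to compound 3 (1.50 log units; beyond the scatter), the first step read at this place on the ring, and a large one. Its full size stays open, since compound 1 is known only by a limit of the assay: the limit of < 5000 nM in this assay, at which 1 of the 3 values shown sits.

The compounds shown leave open whether a hydroxyl or a methoxy group in the same place would give a step of like size. They also leave open whether amino would do so elsewhere on that ring.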